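Swapping the Side Chain on Compound 3

The source may report more compounds than this note shows. Statements on the series, on what has been measured and on what is new or still open speak of the compounds shown alone.

Compound 1 (`COc1cccc2cc(-c3ccccc3)c(O)nc12`): 10000 nM
Compound 2 (`COc1ccc(-c2cc3c(OC)ccc(OC)c3nc2O)cc1`): 10000 nM
Compound 3 (`CCN(CC)C(=O)Cn1c(=O)c(-c2ccc(OC)cc2)cc2c(OC)cc(OC)cc21`): 10000 nM

All three compounds were tested in a functional assay on A-427 cells (Homo sapiens) for cytotoxicity, read by colorimetric assay and MTT assay (a lower number here means a stronger inhibitor, a higher number a weaker inhibitor), and they give the same number. Compound 3 therefore stands level with both others, and nothing separates the three beyond the usual scatter of repeated measurements.

The next compound to be tested is compound 4 (`COc1ccc(-c2cc3c(OC)cc(OC)cc3n(CCCC#N)c2=O)cc1`). Among the measured compounds shown here, it keeps the shared core of compound 3, and only one part changes: 2-cyanoethyl stands in place of diethylcarbamoyl on a saturated chain carbon bound to an aromatic nitrogen (2-cyanoethyl in place of diethylcarbamoyl on a saturated chain carbon bound to an aromatic nitrogen).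

For the measured compounds named here, no measured pair of compounds differs in just one place, so the data do not show directly what this swap does. Going by the values given here, the only guide is the flat picture so far. Compound 3 reads 10000 nM even though its structure differs from compound 1 in more than one place, and compound 1 reads 10000 nM in the same test. On that basis, no step beyond the scatter is expected in this assay, though a modest gain in strength cannot be ruled out.

The expected step is small or absent (no change at the digits printed from compound 3 to compound 4 (within the scatter)).

The estimated value for compound 4 is 10000 nM (expected range 3000 nM to 20000 nM).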

Compound 4, half-maximal inhibitory concentration: 10000 nM
The estimate for compound 4 equals the measured number at the digits printed, within the range that was stated.
By their numbers in this assay, from the lowest: compounds 1, 2, 3 and 4 (each within the scatter of the next).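

Among the compounds shown here, replacing diethylcarbamoyl with 2-cyanoethyl on a saturated chain carbon bound to an aromatic nitrogen gives no change at the digits printed from compound 3 to compound 4 (within the scatter) in this assay, the first direct reading of a single change at this place. The group that leaves has 7 heavy atoms and a double bond, while the one that enters has 4 heavy atoms and a triple bond; each has 1 hydrogen-bond acceptor and neither has a hydrogen-bond donor, yet this exchange does not separate the two compounds in this assay. Nothing measured here offers an explanation for this result.

Going by these compounds, whether any group at this place can shift the value in this assay remains open, and a carboxylic acid, a dimethylamino group or a benzyl group would each test that with a different kind of side chain. On these data alone, it is also open whether changing the methoxy groups on the shared core, for example to hydroxyl groups, would move the value when the side chain of compound 3 or compound 4 is kept.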